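Fluorine for methyl on the benzylidene arm

The source may report more compounds than this note shows. Statements on the series, on what has been measured and on what is new or still open speak of the compounds shown alone.

Measured so far:
Compound 1, `C=CCn1c(=O)/c(=C\c2ccccc2Cl)[nH]c(=O)/c1=C\c1ccccc1OC`: 5100 nM
Compound 2, `C=CCn1c(=O)/c(=C\c2ccc(C)cc2)[nH]c(=O)/c1=C\c1ccccc1OC`: "not active" (no number reported)

In a functional assay on HeLa cells (Homo sapiens) for cytotoxicity, read by CCK-8 assay, with a stated time of 72 h (a lower number here means a stronger inhibitor, a higher number a weaker inhibitor), compound 1 gives 5100 nM. Compound 2 is reported in this assay only as "not active" (no number reported), so no number places it against compound 1. The change is 2-fluorophenyl in place of 4-methylphenyl on a double-bonded chain carbon bound to an aromatic carbon, giving compound 3, `C=CCn1c(=O)/c(=C\c2ccccc2F)[nH]c(=O)/c1=C\c1ccccc1OC`. With no numbered step from compound 2, the size of the move in this assay cannot be counted; the 2-chlorophenyl analogue compound 1 gives 5100 nM, which suggests compound 3 may fall near that weak range. Compound 3 is expected to give about 9000 nM, within 3000 nM to 40000 nM.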

Compound 3, half-maximal inhibitory concentration: 45000 nM
The estimate for compound 3 lay 5.0-fold (0.70 log units) below the measured number, outside the stated range (above it).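

In this assay, the identity of the halogen on the phenyl ring at this position counts: fluoro in place of chloro gives an 8.8-fold higher number from compound 1 to compound 3 (0.95 log units; beyond the scatter), so the 2-fluorophenyl and 2-chlorophenyl groups are not interchangeable here. The step from compound 2 to compound 3 cannot be read, as compound 2 has no number. No measurement offered here accounts for the change in potency.

Still open, going by these compounds, is how a bromo group at the same place of the phenyl ring would read. So is whether an amine or a carboxylic acid there would give a lower number than compound 1.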